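Piperazin-1-yl to 4-methylpiperazin-1-yl: one small step

This account rests on a few compounds, and the source may have more. Where it says the series, first, only, none or still open, it means among the compounds named here.

Three compounds share one core and differ in a single group on an aromatic carbon. In a functional assay on MDA-MB-231 cells (Homo sapiens) for inhibition, read by MTT assay, with a stated time of 72 h (a lower number here means a stronger inhibitor, a higher number a weaker inhibitor), compound 1 `CC(C)(C)n1cc2c(n1)C(=O)CC1(CCN(C(=O)c3cc(-c4ccc(N)cc4)nc4ccccc34)CC1)O2`, with 4-aminophenyl, gives 4960 nM. With pyridin-4-yl, compound 2 `CC(C)(C)n1cc2c(n1)C(=O)CC1(CCN(C(=O)c3cc(-c4ccncc4)nc4ccccc34)CC1)O2` gives 1650 nM, and with piperazin-1-yl, compound 3 `CC(C)(C)n1cc2c(n1)C(=O)CC1(CCN(C(=O)c3cc(N4CCNCC4)nc4ccccc34)CC1)O2` gives 4200 nM.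

On these numbers compound 3 stands near the top of the range. The data show a 1.2-fold lower number from compound 1 to compound 3 (0.07 log units; within the scatter), and also a 2.5-fold higher number from compound 2 to compound 3 (0.41 log units; beyond the scatter).

Compound 4 `CN1CCN(c2cc(C(=O)N3CCC4(CC3)CC(=O)c3nn(C(C)(C)C)cc3O4)c3ccccc3n2)CC1` alters compound 3 in one place: methyl in place of hydrogen on an amine nitrogen in a ring. Among the measured compounds shown here, no measured pair makes this exact change, so the evidence is indirect. Swapping the whole group gave, at its largest, a 3.0-fold lower number from compound 1 to compound 2 (0.48 log units; beyond the scatter), a modest move. A single added methyl is therefore expected to give no step beyond the scatter in this assay, in either direction.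

The expected step is a 1.2-fold lower number from compound 3 to compound 4 (0.07 log units; within the scatter). For compound 4 the estimate is 3600 nM, with an expected range of 1800 nM to 7000 nM.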

Compound 4, half-maximal inhibitory concentration: 8130 nM
Compound 4: middle estimate off by 2.3-fold (0.35 log units), on the low side; measured number outside the range, above it.
By their numbers in this assay, from the lowest: compound 2; then compounds 3, 1 and 4 (each within the scatter of the next).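

In (this assay), a single methyl on the amine nitrogen of the ring is the smallest change yet seen at this position, and it gives (a 1.9-fold higher number from compound 3 to compound 4 (0.29 log units; within the scatter)), so that hydrogen can be replaced by methyl without a step that stands clear of the scatter. Among the compounds shown here, the 4-methylpiperazin-1-yl group also stays close to 4-aminophenyl (a 1.6-fold higher number from compound 1 to compound 4 (0.21 log units; within the scatter)), whereas pyridin-4-yl remains the one group here that stands apart from all the others, with the lowest number (a 4.9-fold higher number from compound 2 to compound 4 (0.69 log units; beyond the scatter)). No measurement here offers an explanation for these steps.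

The compounds shown leave open whether ethyl, a longer chain or an acetyl group on the same nitrogen would also stay within the scatter of compound 3. They also leave open whether pyridin-3-yl would match pyridin-4-yl at this position.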